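Removing the methylene between imidazole and chain carbon

The source may report more compounds than this note shows. Statements on the series, on what has been measured and on what is new or still open speak of the compounds shown alone.

Working notes on the series. Compound 1 `CC(C)C(Cc1ncc[nH]1)c1ccc(-c2ccc3cccc(F)c3c2)[nH]c1=O` is measured in an assay on CHO cells for displacement of a labelled ligand from prostaglandin E2 receptor EP3 subtype (Homo sapiens), read by radioligand binding (a lower number here means a stronger inhibitor, a higher number a weaker inhibitor), where compound 1 gives 11 nM. Among the three compounds measured, compound 1 stands second highest. Its nearest neighbour is compound 3 `Cc1nc(C(c2ccc(-c3ccc4cccc(F)c4c3)[nH]c2=O)C(C)C)[nH]c1C`, which in this assay gives 7 nM; the step from compound 1 to compound 3 is a 1.6-fold lower number from compound 1 to compound 3 (0.20 log units; within the scatter). Furthest away is compound 2 `CCn1ncc2c(F)cc(-c3ccc(C(CC)(CC)c4nnc(C)[nH]4)c(=O)[nH]3)cc21`, which gives 34 nM; the two values of compound 1 and compound 2 lie beyond the scatter of each other, and no single-place step connects them.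

Compound 4 `CC(C)C(c1ncc[nH]1)c1ccc(-c2ccc3cccc(F)c3c2)[nH]c1=O` is not yet measured. Its difference from compound 1 is 1H-imidazol-2-yl in place of (1H-imidazol-2-yl)methyl on a saturated chain carbon bound to an aromatic carbon and a saturated chain carbon.

Within the data shown here, the only measured step that bears on this change is the one from compound 1 to compound 3, which also replaces the (1H-imidazol-2-yl)methyl on that chain carbon with an azole bound directly to it and stays within the scatter. Compound 2 carries a directly bound azole too, but differs in several other places, so its value only shows that such a pattern can sit higher. The expectation for compound 4 is therefore a step of a 1.2-fold higher number from compound 1 to compound 4 (0.07 log units; within the scatter), none beyond the scatter. Compound 4 is estimated at 13 nM, with a range from 4 nM to 40 nM.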

Compound 4, inhibition constant: 7.3 nM
Compound 4: middle estimate off by 1.8-fold (0.25 log units), on the high side, and the stated range covers the measured number.
By their numbers in this assay, from the lowest: compounds 3, 4 and 1 (each within the scatter of the next); then compound 2.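

In this assay, the step of a 1.5-fold lower number from compound 1 to compound 4 (0.18 log units; within the scatter) stays within the scatter, so at this saturated chain carbon the (1H-imidazol-2-yl)methyl group can give way to 1H-imidazol-2-yl without a change that can be read. Compound 3 could not show this alone, since its 4,5-dimethyl-1H-imidazol-2-yl group differs from the group in compound 1 in two respects at once: the methylene is gone and the dimethyl substitution is present. The step of a 1.0-fold higher number from compound 3 to compound 4 (0.02 log units; within the scatter) separates the two, showing that the value of compound 3 does not depend on the dimethyl substitution, and that compounds 1, 3 and 4 cannot be told apart in this assay; no measurement on hand gives a reason for this tolerance.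

The compounds shown leave open how far this tolerance extends, as all three groups at this carbon are imidazole-based and none places a different kind of group there. A longer chain ending in 1H-imidazol-2-yl, or an amine or a carboxylic acid in place of 1H-imidazol-2-yl on the same saturated chain carbon, would test whether the imidazole itself is needed.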